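Expected effect of chloro for fluoro in compound 4

The compounds below may be only part of what the source reports. "The series", "measured", "known", "first", "only" and "open" are said of these compounds alone.

Compound 1 `O=C(CSc1nc(Nc2ccccc2)c2ccccc2n1)Nc1ccccc1F`, compound 2 `O=C(CSc1nc(Nc2ccccc2)c2ccccc2n1)Nc1ccccc1Cl` and compound 3 `O=C(CSc1nc(Nc2ccccc2)c2ccccc2n1)Nc1ccc(F)cc1` share one core and differ only in the group on the amide-type nitrogen. In a functional assay on MGC-803 cells (Homo sapiens) for inhibition, read by MTT assay, with a stated time of 72 h (on this read-out lower numbers stand for stronger inhibition and higher numbers for weaker inhibition), compound 1 gives 10700 nM and compound 2 gives 24800 nM. For compound 3 this assay reports only a limit, > 50000 nM, namely (the limit of > 50000 nM in this assay, at which 1 of the 3 values shown sits). The change from compound 1 to compound 2 is chloro in place of fluoro on an aromatic carbon; it brought a 2.3-fold higher number from compound 1 to compound 2 (0.37 log units; beyond the scatter). Compound 3 differs from compound 1 by 4-fluorophenyl in place of 2-fluorophenyl on an amide-type nitrogen, which gave an at least 4.6-fold higher number from compound 1 to compound 3 (0.66 log units; beyond the scatter). Compound 4 `O=C(CSc1nc(Nc2ccccc2)c2ccccc2n1)Nc1ccc(Cl)cc1` carries the same kind of change relative to compound 3, (chloro in place of fluoro on an aromatic carbon), now sitting para to a large group instead of ortho to a large group. Resting on a 2.3-fold higher number from compound 1 to compound 2 (0.37 log units; beyond the scatter), compound 4 is expected to show a step that the limit leaves unreadable from compound 3 to compound 4, most likely again only a limit. Compound 4 is estimated at 90000 nM in this assay.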

Compound 4, half-maximal inhibitory concentration: 40400 nM
The estimate for compound 4 lay 2.2-fold (0.35 log units) above the measured number, within the range that was stated.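

In this assay, chloro in place of fluoro did not behave the same way on the two cores: the same change on two cores in this assay, a 2.3-fold higher number (0.37 log units; beyond the scatter) from compound 1 to compound 2 and an at least 1.2-fold lower number (0.09 log units; that floor lies within the scatter) from compound 3 to compound 4, at least 2.8-fold (0.45 log units) apart, beyond the scatter of two such steps. Compound 3 is known only through a limit: the limit of > 50000 nM in this assay, at which 1 of the 4 values shown sits. The step of an at least 1.2-fold lower number from compound 3 to compound 4 (0.09 log units; that floor lies within the scatter) is therefore only a floor, so the pairs show that the step from compound 1 to compound 2 cannot simply be carried over, but not how large the change really is on the second core.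

Between the chlorinated compounds the step is a 1.6-fold higher number from compound 2 to compound 4 (0.21 log units; within the scatter), and the wider comparison gives a 3.8-fold higher number from compound 1 to compound 4 (0.58 log units; beyond the scatter). On these data alone, whether a bromo or a methoxy group on the same ring would follow either pattern stays open.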